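The source may report more compounds than this note shows. Statements on the series, on what has been measured and on what is new or still open speak of the compounds shown alone.

In a functional assay on A549 cells (Homo sapiens) for cytotoxicity, read by MTT assay, with a stated time of 72 h (on this read-out lower numbers stand for stronger inhibition and higher numbers for weaker inhibition), two compounds with a shared core have been measured so far. Compound 1 `COc1ccc(/C=N/NC(=O)Nc2cc3c(Nc4ccc(F)c(Cl)c4)ncnc3cc2OC)cc1` carries 4-methoxyphenyl on a carbon with a double bond to nitrogen and gives 28100 nM as its value, while compound 2 `COc1cc2ncnc(Nc3ccc(F)c(Cl)c3)c2cc1NC(=O)N/N=C/c1cc(OC)c(OC)c(OC)c1` carries 3,4,5-trimethoxyphenyl there and gives 32100 nM as its value. Compound 2 therefore stands level with compound 1 within the usual scatter, and the pair cannot be ranked. Compound 3 `COc1cc2ncnc(Nc3ccc(F)c(Cl)c3)c2cc1NC(=O)N/N=C/c1ccc(O)c(Br)c1` differs from compound 2 at that same place (3-bromo-4-hydroxyphenyl in place of 3,4,5-trimethoxyphenyl on a carbon with a double bond to nitrogen) and has 3-bromo-4-hydroxyphenyl in place of 3,4,5-trimethoxyphenyl. Among the compounds with values here, the only measured step at this place (a 1.1-fold higher number from compound 1 to compound 2 (0.06 log units; within the scatter)) stayed within the scatter. However, the entering group appears in neither measured compound, so that single step offers only thin guidance. With nothing pointing either way, no step beyond the scatter is expected in this assay for this swap, and the estimated change (a 1.2-fold lower number from compound 2 to compound 3 (0.09 log units; within the scatter)) is small. The estimate for compound 3 is 26000 nM as a middle value, with 10000 nM to 60000 nM as its expected range.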

Compound 3, half-maximal inhibitory concentration: 28600 nM
Estimate against measurement, compound 3: 1.1-fold (0.04 log units) below; measured number inside the range.
By their numbers in this assay, from the lowest: compounds 1, 3 and 2 (each within the scatter of the next).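

In this assay, 3-bromo-4-hydroxyphenyl in place of 3,4,5-trimethoxyphenyl gives (a 1.1-fold lower number from compound 2 to compound 3 (0.05 log units; within the scatter)), and the same group in place of 4-methoxyphenyl gives (a 1.0-fold higher number from compound 1 to compound 3 (0.01 log units; within the scatter)), so the three compounds stand level and cannot be ranked. The earlier pair differed only in how many methoxy groups the ring carried, whereas the entering group brings a bromine and a hydroxy group, has fewer heavy atoms than 3,4,5-trimethoxyphenyl and adds a hydrogen-bond donor, yet the number stays within the scatter. Nothing available explains why these three values sit so close together.

From the compounds shown here alone, all three compounds keep a six-membered aromatic ring of carbon at this place, so it remains open whether the numbers would stay level with a group of a different kind there, such as a simple alkyl chain, an aliphatic amine or a carboxylic acid. The shared core is also identical in all three, so these compounds cannot tell whether a change elsewhere in the molecule would shift the values more than any change at this place has.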